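Sulfanyl to benzylamino on the shared core

The source may report more compounds than this note shows. Statements on the series, on what has been measured and on what is new or still open speak of the compounds shown alone.

For the measured compounds named here, compound 2 `Nc1cc(N)c2nc(-c3ccccc3)c(Sc3ccc(F)cc3)nc2c1` is the one member of the series for which a functional assay on MDA-MB-435 cells (Homo sapiens) for inhibition, read by sulforhodamine B assay, with a stated time of 48 h (a lower number here means that less compound is tolerated, a higher number that more compound is tolerated), has returned a number: compound 2 gives 66100 nM. Compound 1 `CCOC(=O)[C@H](CCC(=O)O)NC(=O)c1ccc(Sc2nc3cc(N)cc(N)c3nc2-c2ccccc2)cc1` carries an ester-bearing acid side chain and reaches only a limit, < 100000 nM. Compound 3 `CCOC(=O)[C@H](CCC(=O)O)NC(=O)c1ccc(Oc2nc3cc(N)cc(N)c3nc2-c2ccccc2)cc1` is the oxygen-linked counterpart; in this assay compound 3 likewise stops at a limit, < 100000 nM. So compound 2 stands alone as the measured point, while the limit of < 100000 nM in this assay, at which 2 of the 3 values shown sit, covers the rest, and no pair of measured compounds differs in a single place, so no measured step can be drawn on.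

Compound 4 `Nc1cc(N)c2nc(-c3ccccc3)c(NCc3ccc(F)cc3)nc2c1` is the next candidate. Relative to compound 2 the change is (4-fluorobenzyl)amino in place of (4-fluorophenyl)sulfanyl on an aromatic carbon.

With no measured step of this kind in hand, the expectation for this assay rests on compound 2 alone. The entering group adds a hydrogen-bond donor and a one-carbon spacer, but nothing measured here ties either to the read-out. The step from compound 2 to compound 4 is therefore expected to be modest, at most a shift toward less compound tolerated, and plausibly within the scatter, giving an estimated 1.7-fold lower number from compound 2 to compound 4 (0.22 log units; within the scatter). Compound 4 is estimated at 40000 nM, with a range from 12000 nM to 100000 nM.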

Compound 4, concentration lethal to 50% of the cells: 6920 nM
Estimate against measurement, compound 4: 5.8-fold (0.76 log units) above; measured number below the stated range.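

This position on the shared core, the aromatic carbon next to the ring nitrogen, responds clearly in this assay: (4-fluorobenzyl)amino in place of (4-fluorophenyl)sulfanyl gives a 9.6-fold lower number from compound 2 to compound 4 (0.98 log units; beyond the scatter), so less compound is tolerated with the entering group. For the compounds shown here, until this step, the series offered a single number and no measured pair differing in one place, and compounds 1 and 3 still cannot be read against either compound: the limit of < 100000 nM in this assay, at which 2 of the 4 values shown sit. The change is nevertheless a composite one, as it replaces the sulfur link with a nitrogen link, adds a methylene and brings in a hydrogen-bond donor that the leaving group lacks, and this step cannot assign the shift to any one of these.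

A (4-fluorophenyl)amino group, with the nitrogen link but no methylene, and a (4-fluorobenzyl)sulfanyl group, with the methylene but the sulfur link, would separate these parts of the change. Also open is whether the step carries over to compounds with the ester-bearing acid side chain of compound 1, where a (4-fluorobenzyl)amino-type link at this position has no counterpart among the compounds shown.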